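Replacing a trifluoromethyl on sulfonyl with an aryl group

This account rests on a few compounds, and the source may have more. Where it says the series, first, only, none or still open, it means among the compounds named here.

Compound 1 `N#CCCn1cc(-c2nc(Nc3ccc4c(c3)CCN4S(=O)(=O)C(F)(F)F)ncc2F)cn1`: 142 mL.min-1.g-1
Compound 2 `N#CCCn1cc(-c2nc(Nc3ccc4c(c3)CCN4S(=O)(=O)c3ccc(C(F)(F)F)cc3)ncc2F)cn1`: 150 mL.min-1.g-1
Compound 3 `N#CCCn1cc(-c2nc(Nc3ccc4c(ccn4S(=O)(=O)C(F)(F)F)c3)ncc2F)cn1`: 11.4 mL.min-1.g-1

In an ADME assay on microsomes from liver (Homo sapiens) for metabolic stability (on this read-out higher numbers stand for fast clearance and lower numbers for slow clearance), compound 1 gives 142 mL.min-1.g-1 and compound 2 gives 150 mL.min-1.g-1. The change between them, (4-(trifluoromethyl)phenyl in place of trifluoromethyl on a sulfonyl sulfur), gave a 1.1-fold higher number from compound 1 to compound 2 (0.02 log units; within the scatter). Compound 3 gives 11.4 mL.min-1.g-1 in this assay; how its core differs from that of compound 1 is not broken down here. Compound 4 `N#CCCn1cc(-c2nc(Nc3ccc4c(ccn4S(=O)(=O)c4ccc(C(F)(F)F)cc4)c3)ncc2F)cn1` carries the same kind of change, (4-(trifluoromethyl)phenyl in place of trifluoromethyl on a sulfonyl sulfur), but the sulfonyl sulfur here sits on an aromatic nitrogen rather than on a sulfonamide nitrogen in a ring. Because a 1.1-fold higher number from compound 1 to compound 2 (0.02 log units; within the scatter) stayed within the scatter, compound 4 is expected to show a 1.2-fold higher number from compound 3 to compound 4 (0.09 log units; within the scatter) in this assay. Compound 4 is estimated at 14 mL.min-1.g-1, between 6 mL.min-1.g-1 and 35 mL.min-1.g-1.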

Compound 4, intrinsic clearance in microsomes: 36.4 mL.min-1.g-1
The estimate for compound 4 lay 2.6-fold (0.41 log units) below the measured number; the whole stated range lies below it.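

In this assay, putting 4-(trifluoromethyl)phenyl in place of trifluoromethyl on a sulfonyl sulfur gave a 3.2-fold higher number from compound 3 to compound 4 (0.50 log units; beyond the scatter). The size of this change therefore did not carry over from one core to the other, since the two steps differ beyond the scatter: the same change on two cores in this assay, a 1.1-fold higher number (0.02 log units; within the scatter) from compound 1 to compound 2 and a 3.2-fold higher number (0.50 log units; beyond the scatter) from compound 3 to compound 4, 3.0-fold (0.48 log units) apart, beyond the scatter of two such steps

This rests on one pair per core, and it does not show which feature of the cores sets the two steps apart or what a further core would give. The compounds shown leave open how other groups on the sulfonyl sulfur, such as a methyl or an unsubstituted phenyl, would behave on these two cores. They also leave open whether a change elsewhere, such as an amine in place of the nitrile, would depend on the core in the same way.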